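This account rests on a few compounds, and the source may have more. Where it says the series, first, only, none or still open, it means among the compounds named here.

Working notes on the series. Compound 1 `Cc1nc(NCC(C)C)nc(N[C@@H]2C[C@H](CO)[C@@H](O)[C@H]2O)c1-c1nc2ccccc2s1` stands highest of the two numbers available in an ADME assay on the whole organism (plasma) for pharmacokinetics, with Rattus norvegicus as the target, with a stated time of 6 h, at a dose of 10 mg/kg by the oral route (a lower number here means less compound in the circulation, a higher number more compound in the circulation at the dose given), where compound 1 gives 1020 ng.h/mL. Among the measured compounds shown here, compound 2 `CCOC(=O)NCCNc1nc(C)c(-c2nc3ccccc3s2)c(N[C@@H]2C[C@H](CO)[C@@H](O)[C@H]2O)n1` gives 151 ng.h/mL in this assay, and the one measured step, a 6.8-fold lower number from compound 1 to compound 2 (0.83 log units; beyond the scatter), replaces the isopropyl on the saturated chain carbon bound to a nitrogen on the aromatic ring.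

Compound 3 `Cc1nc(NCc2ccccn2)nc(N[C@@H]2C[C@H](CO)[C@@H](O)[C@H]2O)c1-c1nc2ccccc2s1` differs from compound 1 at that same position: pyridin-2-yl in place of isopropyl on a saturated chain carbon bound to a nitrogen on an aromatic ring. The measured step bears on this only loosely, since what enters there is an ethyl carbamate chain rather than a six-membered aromatic ring with one hetero atom; it does show that a change at this position can move this assay beyond the scatter, and in the lower direction. A lower number is therefore expected for compound 3, with a step of a 2.6-fold lower number from compound 1 to compound 3 (0.41 log units; beyond the scatter) estimated as smaller than the measured one. The value expected for compound 3 is 400 ng.h/mL, within a range of 150 ng.h/mL to 1000 ng.h/mL.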

Compound 3, area under the concentration-time curve: 1630 ng.h/mL
For compound 3 the middle estimate is 4.1-fold (0.61 log units) below the measured one, outside the stated range (above it).
By their numbers in this assay, from the lowest: compound 2; then compounds 1 and 3 (each within the scatter of the next).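

Pyridin-2-yl in place of isopropyl on a saturated chain carbon bound to a nitrogen on an aromatic ring gives a 1.6-fold higher number from compound 1 to compound 3 (0.20 log units; within the scatter) in this assay, so this place accepts a six-membered aromatic ring with one hetero atom without separating the two compounds in this read-out. The drop seen earlier is therefore not general to changes at this position: pyridin-2-yl in place of ((ethoxycarbonyl)amino)methyl gives an 11-fold higher number from compound 2 to compound 3 (1.03 log units; beyond the scatter), and among the three compounds the low number stands with compound 2 alone. Nothing available bears on why these numbers fall as they do.

Still open, on these data alone, is whether phenyl at this place would read as pyridin-2-yl does. Also open, as far as these compounds go, is whether an amine or a carboxylic acid in place of the ethyl carbamate would give a number as low as that of compound 2.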